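Piperazine amide variation in a maximal electroshock screen

The source may hold more compounds than are shown below. What is called first, only, known or untested is meant among the compounds shown, and "the series" means these compounds.

Measured compounds:
compound 1, `CC1(c2ccccc2)CC(=O)N(CC(=O)N2CCN(c3ccccc3F)CC2)C1=O`, 100 mg/kg
compound 2, `CC1(c2ccccc2)CC(=O)N(CC(=O)N2CCN(c3ccccc3)CC2)C1=O`, 300 mg/kg
compound 3, `CC1(c2ccccc2)CC(=O)N(CC(=O)N2CCN(c3cccc(Cl)c3Cl)CC2)C1=O`, "not active" (no number reported)

Of the compounds shown here, three sharing one core have been tested in a functional assay on the whole organism (strain CD-1) with Mus musculus as the target, in the maximal electroshock model, with a stated time of 0.5 h; a higher number here means that more compound is needed for the effect, a lower number that less compound is needed. Compound 1 gives 100 mg/kg and stands lowest of the two numbers available. Compound 2 gives 300 mg/kg. Compound 3 was found to be "not active" (no number reported), so no number is available for it. Among the measured compounds shown here, the only single-point step measured is a 3.0-fold higher number from compound 1 to compound 2 (0.48 log units; beyond the scatter), where a hydrogen replaces the fluoro on the aromatic carbon; it lies beyond the scatter and is modest in size.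

Compound 4, `CC1(c2ccccc2)CC(=O)N(CC(=O)N2CCN(c3cccc(C(F)(F)F)c3)CC2)C1=O`, has not yet been measured. It differs from compound 1 as follows: 3-(trifluoromethyl)phenyl in place of 2-fluorophenyl on an amine nitrogen in a ring. For the measured compounds named here, no measured step covers a trifluoromethyl group at this place, so the step from compound 1 to compound 2 is the nearest guide, and it shows that altering this aromatic ring raised the number; compound 3, which carries two chloro groups there, gave no number at all.

Compound 4 is therefore expected to need a higher dose than compound 1, with the estimated step being a 3.0-fold higher number from compound 1 to compound 4 (0.48 log units; beyond the scatter). The estimate for compound 4 is 300 mg/kg, within a range from 100 mg/kg to 1000 mg/kg, with a real chance that only inactivity is reported.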

Compound 4, minimum effective dose: 300 mg/kg
Beside the measured number, compound 4's estimate shows no gap at the digits printed; the measured number falls inside the stated range.
By their numbers in this assay, from the lowest: compound 1; then compounds 2 and 4 (each within the scatter of the next).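

In this assay, trifluoromethyl in place of hydrogen on the aromatic carbon gives no change at the digits printed from compound 2 to compound 4 (within the scatter), so this substituent on the ring leaves the number where the unsubstituted phenyl ring puts it. Among the compounds shown here, the exchange of 2-fluorophenyl for 3-(trifluoromethyl)phenyl on the amine nitrogen in the ring gives a 3.0-fold higher number from compound 1 to compound 4 (0.48 log units; beyond the scatter), a step of the same printed size as a 3.0-fold higher number from compound 1 to compound 2 (0.48 log units; beyond the scatter), and compound 1 therefore remains the only compound with a number beyond the scatter of the others. A substituted ring can thus still give a number here, although compound 3, with its two chloro groups, gives "not active" (no number reported) and so cannot be placed on the same scale.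

No measurement shown here accounts for either new step. As far as these compounds go, it also remains open how a methoxy group or a nitrile on this aromatic ring would read in this assay, and whether the low number of compound 1 depends on fluoro specifically or would also appear with another small group in its place.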